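Removing one prenyl group from a bis-guanidine inhibitor

The compounds below may be only part of what the source reports. "The series", "measured", "known", "first", "only" and "open" are said of these compounds alone.

Measured compounds:
- compound 1 `CC(C)=CCNC(=N)NCCCCCN`: 10 nM
- compound 2 `CC(C)=CCNC(=N)NCCCCNC(=N)NCC=C(C)C`: 1500 nM

Compound 1 carries a single guanidine with a 3-methylbut-2-en-1-yl group and a free amine at the far end of the chain; in an assay on isolated protein for inhibition of polyamine oxidase 1 (Zea mays), read by spectrophotometry, using a Dixon plot, at pH 6.5 (on this read-out higher numbers stand for weaker inhibition and lower numbers for stronger inhibition), compound 1 gives 10 nM. Compound 2 carries two guanidines, each bearing a 3-methylbut-2-en-1-yl group; in this assay compound 2 gives 1500 nM, the higher of the two numbers and therefore the weaker inhibitor, well beyond the scatter from compound 1.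

Compound 3 `CC(C)=CCNC(=N)NCCCCNC(=N)N` is the next compound. The change from compound 2 to compound 3 is hydrogen in place of 3-methylbut-2-en-1-yl on an amine nitrogen. It keeps the two guanidines of compound 2 but leaves one of them unsubstituted, so that one end of the molecule now resembles the free amine end of compound 1.

With only these two measured compounds as guide, the expected step from compound 2 to compound 3 is a clear drop in the number, a 15-fold lower number from compound 2 to compound 3 (1.18 log units; beyond the scatter), beyond the scatter. The estimate for compound 3 in this assay is 100 nM, with a range from 20 nM to 600 nM.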

Compound 3, inhibition constant: 700 nM
Compound 3: the middle estimate sits 7.0-fold (0.85 log units) below what was measured; measured number above the stated range.
By their numbers in this assay, from the lowest: compound 1; then compound 3; then compound 2.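

In this assay the 3-methylbut-2-en-1-yl group on the amine nitrogen turns out to matter little: removing it gives a 2.1-fold lower number from compound 2 to compound 3 (0.33 log units; beyond the scatter), a modest step that is still beyond the usual scatter, so a bare guanidine at this end is tolerated but gains only a little. The far end of the chain shows a much larger difference, where a free amine on compound 1 gives way to an unsubstituted guanidine on compound 3, with a 70-fold higher number from compound 1 to compound 3 (1.85 log units; beyond the scatter) and so a large loss of inhibition. Nothing measured here explains either step.

The compounds shown leave open how much of the larger step comes from the guanidine itself and how much from the chain that carries it, since that one change replaces a whole end group. They also do not show whether a smaller group such as methyl or ethyl on this nitrogen would behave like hydrogen or like 3-methylbut-2-en-1-yl, or what a longer chain between the two guanidines would do.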